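Cytotoxicity notes on compounds 1 to 3

The source may report more compounds than this note shows. Statements on the series, on what has been measured and on what is new or still open speak of the compounds shown alone.

compound 1 `CC(C)N(Cc1cccc(OCCCCCC(=O)O)c1)C(=O)c1ccc(-c2ccncc2)cc1` — in an ADME assay on HepG2 cells (Homo sapiens) for cytotoxicity, read by CellTiter-Glo and resazurin assay, with a stated time of 72 h (on this read-out lower numbers stand for an effect already at smaller amounts and higher numbers for an effect only at larger amounts of compound), compound 1 gives > 26000 nM, a limit of the assay.
compound 2 `CC(C)N(Cc1cccc(OCCCCCC(=O)O)c1)C(=O)c1ccc(-c2cccc(S(C)(=O)=O)c2)cc1` — in this assay compound 2 gives > 26000 nM, a limit of the assay.

Compound 2 stands at the limit only: its reading in this assay is one of the two that sit at the limit of > 26000 nM in this assay, at which 2 of the 2 values shown sit, and no number is given for it. The step that the two limits leave unreadable from compound 1 to compound 2 therefore cannot be read. Compound 3 `CC(C)N(Cc1cccc(OCCCCCC(=O)O)c1)C(=O)c1ccc(-c2cccc([N+](=O)[O-])c2)cc1` differs from compound 2 by nitro in place of methylsulfonyl on an aromatic carbon. Going by the values given here, only the step from compound 1 to compound 2 bears on this change, and it is unreadable, since both readings sit at the limit of > 26000 nM in this assay, at which 2 of the 2 values shown sit. Among the compounds with values here, no measured step points to a direction, so in this assay no step beyond the scatter is expected, and the step that the limit leaves unreadable from compound 2 to compound 3 is estimated as flat. For compound 3 the expected value in this assay is 30000 nM, within 15000 nM to 60000 nM, most likely again reported only as a limit.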

Compound 3, half-maximal effective concentration: > 26000 nM
Compound 3: a limit, no number (the forecaster's own chance of this, stated with the estimate: 80%); the middle value is on the limit's open side.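

Going by these compounds alone, no step among compound 1, compound 2 and compound 3 can be read in this assay, since each reading is a limit and not a number: the limit of > 26000 nM in this assay, at which 3 of the 3 values shown sit.

The compounds shown leave open whether pyridin-4-yl, 3-(methylsulfonyl)phenyl and 3-nitrophenyl differ at all in cytotoxicity on the shared core.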